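This account rests on a few compounds, and the source may have more. Where it says the series, first, only, none or still open, it means among the compounds named here.

Compound 1 `OC(c1ccc(Cl)cc1)(c1cccnc1)c1ccccc1Br`: 55200 nM
Compound 2 `OC(c1ccc(Cl)cc1)(c1cccnc1)c1cccc(Br)c1`: 54100 nM
Compound 3 `OC(c1ccc(Cl)cc1)(c1cccnc1)c1ccccc1C(F)(F)F`: 59300 nM

These three compounds share one core and were tested in an ADME assay on L6 cells (Rattus norvegicus) for cytotoxicity, read by resazurin assay, with a stated time of 72 h; on this read-out lower numbers stand for stronger inhibition and higher numbers for weaker inhibition. Compound 1 and compound 2 are built from the same atoms joined differently: 3-bromophenyl in place of 2-bromophenyl on a saturated chain carbon bound to two aromatic carbons and an oxygen on a saturated carbon. That change gave a 1.0-fold lower number from compound 1 to compound 2 (0.01 log units; within the scatter). Compound 3 differs from compound 1 by trifluoromethyl in place of bromo on an aromatic carbon, and that change gave a 1.1-fold higher number from compound 1 to compound 3 (0.03 log units; within the scatter).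

Compound 4 `OC(c1ccc(Cl)cc1)(c1cccnc1)c1cccc(C(F)(F)F)c1` has not yet been measured in this assay. It differs from compound 2 by trifluoromethyl in place of bromo on an aromatic carbon. Among the compounds with values here, this is the same kind of change as the one from compound 1 to compound 3, but not the same: in compound 3 the entering group sits ortho to a large group, in compound 4 meta to a large group. The earlier step of this kind stayed within the scatter. Compound 4 is therefore expected to show a similarly small step, a 1.1-fold higher number from compound 2 to compound 4 (0.02 log units; within the scatter). Compound 4 is estimated at 57000 nM, between 35000 nM and 95000 nM.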

Compound 4, half-maximal inhibitory concentration: 60400 nM
The estimate for compound 4 lay 1.1-fold (0.03 log units) below the measured number, within the range that was stated.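

In this assay, putting trifluoromethyl in place of bromo on compound 2 gave a 1.1-fold higher number from compound 2 to compound 4 (0.05 log units; within the scatter). Set beside the earlier step, the same change looks alike on the two cores: the same change on two cores in this assay, a 1.1-fold higher number (0.03 log units; within the scatter) from compound 1 to compound 3 and a 1.1-fold higher number (0.05 log units; within the scatter) from compound 2 to compound 4, 1.0-fold (0.02 log units) apart, within the scatter of two such steps. This shows that the swap made no measurable difference on either core, but two steps this small cannot show that a larger effect would carry from one core to another, and they show nothing about any other read-out.

On these data alone, it remains open whether an amine or a carboxylic acid in place of bromo would move the number beyond the scatter. As far as these compounds go, it is also open whether changing the hydroxyl on the central carbon, for instance to a methoxy group, would do so.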